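The source may report more compounds than this note shows. Statements on the series, on what has been measured and on what is new or still open speak of the compounds shown alone.

Compound 1, `CCc1ncncc1-c1nc2cc(F)c(F)cc2n1C1CC1`, in an ADME assay on cells for inhibition of cytochrome P450 11B1, mitochondrial (Homo sapiens), read by HPLC, with a stated time of 60 min (a higher number here means a weaker inhibitor, a lower number a stronger inhibitor), gives 3330 nM.
Compound 2, `Fc1cc2nc(-c3cncnc3C3CC3)n(C3CC3)c2cc1F`, in this assay is known only as a limit of the measurement, > 10000 nM.

Compound 2 thus stands at the weak end of what has been measured, sitting at the limit of > 10000 nM in this assay, at which 1 of the 2 values shown sits, rather than at a number of its own. Among the compounds with values here, the single measured step that bears on this position is an at least 3.0-fold higher number from compound 1 to compound 2 (0.47 log units; beyond the scatter), which moved the value out of the measurable range. Compound 3, `N#Cc1ncncc1-c1nc2cc(F)c(F)cc2n1C1CC1`, differs from compound 2 by cyano in place of cyclopropyl on an aromatic carbon. Within the data shown here, no measured step involves a cyano group, so the direction of this change rests only on the observation that the cyclopropyl compound was the weakest of the pair. Compound 3 is therefore expected to come back toward the range of compound 1, a step of an at least 2.0-fold lower number from compound 2 to compound 3 (0.30 log units; that floor lies within the scatter) in this assay, with a wide uncertainty. Compound 3 is estimated at 5000 nM, between 1500 nM and 20000 nM.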

Compound 3, half-maximal inhibitory concentration: 4990 nM
The estimate for compound 3 lay 1.0-fold (0.00 log units) above the measured number, and the stated range covers the measured number.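

Cyano on this aromatic carbon, next to the ring nitrogen, gives a measured number in this assay, which cyclopropyl at the same place did not, with an at least 2.0-fold lower number from compound 2 to compound 3 (0.30 log units; that floor lies within the scatter). Against ethyl the change is a 1.5-fold higher number from compound 1 to compound 3 (0.18 log units; within the scatter), so cyano and ethyl cannot be told apart here, and of the three groups only cyclopropyl stands beyond the scatter from another. Compound 2 remains a limit of the assay and not a number, so only a floor is known for its gap to compound 3: the limit of > 10000 nM in this assay, at which 1 of the 3 values shown sits.

As far as these compounds go, whether any group at this position would give a clearly stronger inhibitor than ethyl or cyano stays open, for instance a methyl group, a chlorine atom or an amine. Also open, from the compounds shown here alone, is whether ethyl and cyano stay level when the rest of the shared core is changed.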